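The compounds below may be only part of what the source reports. "The series", "measured", "known", "first", "only" and "open" are said of these compounds alone.

Compound 1 `C/C=C/C(=O)Nc1cc(Nc2ncc(Cl)c(N3CCc4sccc4C3)n2)c(OC)cc1N(C)CCN(C)C` is the starting point of this comparison. In a functional assay on A-431 cells (Homo sapiens) for cytotoxicity, read by MTT assay (on this read-out higher numbers stand for weaker inhibition and lower numbers for stronger inhibition), compound 1 gives 152 nM, the lowest of the two numbers seen, the other belonging to compound 2 `C=C(Cl)C(=O)Nc1cc(Nc2ncc(Cl)c(N3CCc4sccc4C3)n2)c(OC)cc1N(C)CCN(C)C`, which in this assay gives 13700 nM. Compound 3 `CCC(=O)Nc1ccc(OC)c(Nc2ncc(Cl)c(N3CCc4sccc4C3)n2)c1` differs from compound 1 in more than one place; in this assay compound 3 reaches only a limit of the assay, > 200000 nM, and this is the limit of > 200000 nM in this assay, at which 1 of the 3 values shown sits.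

Among the compounds with values here, the one measured step that changes a single place is a 90-fold higher number from compound 1 to compound 2 (1.95 log units; beyond the scatter). Within the data shown here, both compound 2 and compound 4 `COc1cc(N(C)CCN(C)C)c(NC(=O)C=C(C)C)cc1Nc1ncc(Cl)c(N2CCc3sccc3C2)n1` alter the group carried by the same carbonyl carbon, so this step is the only direct guide. The change to compound 4 is 2-methylprop-1-en-1-yl in place of prop-1-en-1-yl on a carbonyl carbon. It adds one carbon to the group on the carbonyl carbon and keeps the single double bond outside aromatic rings.

The measured step shows that a small change at this place can move the number in this assay a long way toward weaker inhibition. Among the measured compounds shown here, compound 4 is therefore expected to give a higher number than compound 1, with the step of a 20-fold higher number from compound 1 to compound 4 (1.30 log units; beyond the scatter), though smaller than the one seen for compound 2. The estimate for compound 4 in this assay is 3000 nM, with a likely range from 500 nM to 30000 nM.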

Compound 4, half-maximal inhibitory concentration: > 50000 nM
Compound 4 ended at the assay's limit; the forecaster's own chance of this, stated with the estimate: 5%; middle value at least 16-fold (1.22 log units) away from the limit.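

Adding the methyl of 2-methylprop-1-en-1-yl to the group on the carbonyl carbon moves the number in this assay far toward weaker inhibition, giving an at least 320-fold higher number from compound 1 to compound 4 (2.51 log units; beyond the scatter). With a second replacement now also giving a higher number, prop-1-en-1-yl holds the lowest number among the three groups compared at this place, and the two replacements do not land at the same level, giving an at least 3.6-fold higher number from compound 2 to compound 4 (0.56 log units; beyond the scatter). Both steps are minimum sizes, since compound 4 reaches a limit of the assay rather than a number: the limit of > 50000 nM in this assay, at which 1 of the 4 values shown sits.

On these data alone, how far compound 4 actually lies beyond that limit remains open, so the true size of its steps and the full gap between the two replacements are unknown. The compounds shown also leave open whether a plain ethenyl group, or a longer chain such as 4-(dimethylamino)but-2-enyl's counterpart carrying an amine at its far end, would give a lower number than compound 1 or a higher one when placed on the same carbonyl carbon.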